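Notes on the shared core: aminoamino to phenyl on the carbonyl

A few compounds are considered here, and "the series" means these few. Any claim that something is new, unique, unknown or untested is made for them only; others in the source may bear on it.

compound 1 `NNC(=O)c1c(N)sc2c1CCCCCC2`: 48%
compound 2 `Nc1sc2c(c1C(=O)NNc1ccccc1)CCCCCC2`: 43%

In a functional assay on CHO cells for agonist activity at adenosine receptor A1 (Homo sapiens), read by ERK phosphorylation, tested at 10 uM (on this read-out higher numbers stand for a stronger effect at the one concentration tested and lower numbers for a weaker effect), compound 1 gives 48% and compound 2 gives 43%. The step of a number 5 percentage points lower from compound 1 to compound 2 (within the scatter) lies within the scatter, so on these two numbers compound 1 stands level with compound 2. Compound 3 `Nc1sc2c(c1C(=O)c1ccccc1)CCCCCC2` is not yet measured; it differs from compound 1 by phenyl in place of aminoamino on a carbonyl carbon. Within the data shown here, no measured step touches the carbonyl carbon; the only step, a number 5 percentage points lower from compound 1 to compound 2 (within the scatter), changed the amine nitrogen and stayed within the scatter, so it bears only loosely on this change, and the loss of both donors leaves the outcome open. Compound 3 is expected to fall a little, the step of a number 13 percentage points lower from compound 1 to compound 3 (beyond the scatter) being the estimate. Compound 3 is estimated at 35%, with a range from 10% to 60%.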

Compound 3, a percentage reported as activity, at one concentration (the size of the read-out at that concentration, not a potency): 36%
Compound 3: middle estimate off by 1 percentage points, on the low side; low and high end bracket the measured number.
By their numbers in this assay, from the lowest: compounds 3, 2 and 1 (each within the scatter of the next, the first and the last beyond it).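

In this assay, phenyl in place of aminoamino on a carbonyl carbon gives a number 12 percentage points lower from compound 1 to compound 3 (beyond the scatter), a modest step and the first in this series beyond the scatter. Compound 3 still reads 36%, so the read-out survives the loss of the hydrogen-bond donors of aminoamino at this position. No measurement at hand accounts for the step.

Open, going by these compounds, is whether the step follows the departure of aminoamino or the arrival of phenyl. A methyl or a methylamino group on the carbonyl carbon would help separate the two.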